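Replacing the 2-oxopiperidin-1-yl group in compound 3

This account rests on a few compounds, and the source may have more. Where it says the series, first, only, none or still open, it means among the compounds named here.

Measured in a functional assay (aorta) with Rattus norvegicus as the target; a higher number here means that more compound is needed for the effect, a lower number that less compound is needed:
- compound 1 `O=C1CCCN1[C@@H]1c2cc([N+](=O)[O-])ccc2OC(CF)(CF)[C@H]1O`: 24 nM
- compound 2 `N#Cc1ccc2c(c1)[C@@H](N1CCCCC1=O)[C@H](O)C(CF)(CF)O2`: 8.91 nM
- compound 3 `O=C1CCCCN1[C@@H]1c2cc([N+](=O)[O-])ccc2OC(CF)(CF)[C@H]1O`: 2.75 nM

Of these three, compound 3 has the lowest number, at 2.75 nM. Its margin over both others is beyond the scatter: a 3.2-fold lower number from compound 2 to compound 3 (0.51 log units; beyond the scatter) and an 8.7-fold lower number from compound 1 to compound 3 (0.94 log units; beyond the scatter).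

The next compound to be measured is compound 4 `O=c1ccccn1[C@@H]1c2cc([N+](=O)[O-])ccc2OC(CF)(CF)[C@H]1O`. The change is on a saturated ring carbon, where the 2-oxopiperidin-1-yl group gives way to a group with a six-membered aromatic ring with 1 hetero atom: a group of 7 heavy atoms (5 carbon, 1 nitrogen, 1 oxygen; one six-membered aromatic ring with 1 hetero atom) in place of a group of 7 heavy atoms (5 carbon, 1 nitrogen, 1 oxygen; one six-membered non-aromatic ring with 1 hetero atom), on a saturated ring carbon.

The most relevant measured step is an 8.7-fold lower number from compound 1 to compound 3 (0.94 log units; beyond the scatter), which also changes the group on this saturated ring carbon. Among the compounds with values here, it gives a scale for changes at this place, but not a direction, since no measured compound carries an aromatic ring there. The other measured step, a 3.2-fold lower number from compound 2 to compound 3 (0.51 log units; beyond the scatter), is on an aromatic carbon and bears on this change only indirectly. No clear direction is therefore expected in this assay, and a modest step either way remains possible.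

The expected step is a 1.1-fold higher number from compound 3 to compound 4 (0.04 log units; within the scatter). For compound 4 the estimate is 3 nM, with an expected range of 0.8 nM to 11 nM.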

Compound 4, half-maximal effective concentration: 28.8 nM
Compound 4: the middle estimate sits 9.6-fold (0.98 log units) below what was measured; the measured number lies above the stated range.
By their numbers in this assay, from the lowest: compound 3; then compound 2; then compounds 1 and 4 (each within the scatter of the next).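

In this assay, this position separates two groups of equal heavy-atom composition: with a six-membered ring in both, the aromatic ring in place of the non-aromatic 2-oxopiperidin-1-yl group gives a 10-fold higher number from compound 3 to compound 4 (1.02 log units; beyond the scatter). Ring size alone therefore does not account for the low number of compound 3, since the six-membered aromatic group and the five-membered 2-oxopyrrolidin-1-yl group stay level, with a 1.2-fold higher number from compound 1 to compound 4 (0.08 log units; within the scatter), and among the three groups compared at this place with the nitro group held constant, only 2-oxopiperidin-1-yl gives the low number. Nothing available accounts for the loss on going to the aromatic ring.

Still open, from the compounds shown here alone, is whether the low number is confined to 2-oxopiperidin-1-yl or extends to the larger 2-oxoazepan-1-yl ring, and whether the ring carbonyl matters at all, which a plain piperidin-1-yl amine at the same saturated ring carbon would test. Also open, going by these compounds, is whether the aromatic ring costs as much with cyano in place of nitro on the aromatic carbon.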